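Ethoxycarbonyl in Place of Methyl on a Shared Core

A few compounds are considered here, and "the series" means these few. Any claim that something is new, unique, unknown or untested is made for them only; others in the source may bear on it.

Measured so far:
compound 1, `CCn1c(=O)n(C2OC(CO)[C@@H](O)[C@H]2O)c2nc(N)nc(O)c21`: 15 uM
compound 2, `C=CCn1c(=O)n(CCC(CCOCc2ccccc2)CCOCc2ccccc2)c2nc(N)nc(O)c21`: 7 uM

Of the compounds shown here, two with the same core have been measured. In a functional assay (B cells) with Mus musculus as the target (a lower number here means that less compound is needed, a higher number that more compound is needed for the effect), compound 1 gives 15 uM, while compound 2 gives 7 uM. Compound 1 therefore stands at the higher of the two numbers, and compound 2 at the lower; the gap between them lies beyond the usual scatter. Going by the values given here, the two compounds differ from each other in more than one place, so no single structural step links them, and their two values are all that can be said of the pair.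

Compound 3, `CCOC(=O)Cn1c(=O)n(C2OC(CO)[C@@H](O)[C@H]2O)c2nc(N)nc(O)c21`, has not yet been measured in this assay. It differs from compound 1 in one place: ethoxycarbonyl in place of methyl on a saturated chain carbon bound to an aromatic nitrogen. Among the compounds with values here, no measured pair shows a change of this kind, so the expectation rests on the values of compound 1 and compound 2 alone. The step is expected to be small, toward a somewhat higher number and possibly within the scatter: a 1.3-fold higher number from compound 1 to compound 3 (0.12 log units; within the scatter). Compound 3 is accordingly expected to give about 20 uM, in a range from 6 uM to 60 uM.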

Compound 3, concentration for half-maximal effect: 48 uM
The estimate for compound 3 lay 2.4-fold (0.38 log units) below the measured number; the range from low to high includes it.
By their numbers in this assay, from the lowest: compound 2; then compound 1; then compound 3.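

Going by these compounds alone, the comparison gives the first reading at a single place on the shared core, the saturated chain carbon bound to an aromatic nitrogen. In this assay, ethoxycarbonyl in place of methyl gives a 3.2-fold higher number from compound 1 to compound 3 (0.51 log units; beyond the scatter), a modest step but one beyond the scatter, so this position is not indifferent to what it carries. The entering group brings five heavy atoms for one, a double bond outside aromatic rings and two hydrogen-bond acceptors, and with this change more compound is needed for the effect, but nothing available explains the rise.

What remains open is which part of the ethoxycarbonyl group goes with the step: the compounds shown do not separate the added length from the ester itself, and a plain propyl chain, a carboxylic acid or a primary amide at this place would be needed to draw that line. Compound 2 differs from compound 1 and compound 3 in more than one place, so whether the same change would give a similar step on its background also remains unanswered.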